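Trimming the Amine Terminus of Compound 1

The source may report more compounds than this note shows. Statements on the series, on what has been measured and on what is new or still open speak of the compounds shown alone.

Compound 1 `CN(C)CCCOc1ccc(CN(C)c2nc3ccc(Oc4ccc(C(F)(F)F)cc4)cc3s2)cc1` gives 54000 nM in an assay on cells for inhibition of Voltage-dependent T-type calcium channel subunit alpha-1H (Homo sapiens), read by FLIPR and calcium flux, with stated times of 600 s and 300 s (a lower number here means a stronger inhibitor, a higher number a weaker inhibitor), the lowest of the three numbers recorded there. Compound 2 `CN(C)CCCOc1ccc(CN(C)c2nc3ccc(Oc4ccc(C#N)cc4)cc3s2)cc1` gives 64000 nM, and the step of a 1.2-fold higher number from compound 1 to compound 2 (0.07 log units; within the scatter) lies within the scatter. For the measured compounds named here, compound 3 `N=C(N)NCCCOc1ccc(CNc2nc3ccc(Oc4ccc(C(F)(F)F)cc4)cc3s2)cc1` gives 195000 nM, a higher number than compound 1 by more than the scatter, though no single-point step connects the two. Compound 4 `CN(Cc1ccc(OCCCN)cc1)c1nc2ccc(Oc3ccc(C(F)(F)F)cc3)cc2s1` differs from compound 1 by amino in place of dimethylamino on a saturated chain carbon, three bonds along the chain from an oxygen on an aromatic ring. Going by the values given here, no measured step covers this change; the only measured step, a 1.2-fold higher number from compound 1 to compound 2 (0.07 log units; within the scatter), concerns another part of the molecule. Because compound 3, which also carries no dimethylamino group, gives 195000 nM, a moderately higher number seems likely. Compound 4 is therefore expected to give 85000 nM, with a range of 35000 nM to 200000 nM. The expected step is a 1.6-fold higher number from compound 1 to compound 4 (0.20 log units; within the scatter).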

Compound 4, half-maximal inhibitory concentration: 248000 nM
The estimate for compound 4 lay 2.9-fold (0.47 log units) below the measured number; the whole stated range lies below it.
By their numbers in this assay, from the lowest: compounds 1 and 2 (each within the scatter of the next); then compounds 3 and 4 (each within the scatter of the next).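

In this assay, for the compounds shown here, the end of the 3-(dimethylamino)propyl chain proves sensitive to change: amino in place of dimethylamino gives the first single-place step beyond the scatter (a 4.6-fold higher number from compound 1 to compound 4 (0.66 log units; beyond the scatter)). The cyano for trifluoromethyl change at the other end of the molecule stayed within it (a 1.2-fold higher number from compound 1 to compound 2 (0.07 log units; within the scatter)). Nothing available explains the rise in the number. On these data alone, whether methylamino, with one methyl group kept, would give a number nearer that of compound 1 remains open. So does the effect of a cyclic amine such as pyrrolidine or a longer chain at this position.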